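Sulfonyl exchange on the ring nitrogen of compound 2

The source may report more compounds than this note shows. Statements on the series, on what has been measured and on what is new or still open speak of the compounds shown alone.

In a functional assay on QGY-7703 cells (Homo sapiens) for cytotoxicity, read by MTT assay, with a stated time of 24 h (on this read-out higher numbers stand for weaker inhibition and lower numbers for stronger inhibition), compound 2 `CN1C/C(=C\c2cccnc2)C(=O)/C(=C/c2ccccc2C(F)(F)F)C1` gives 2910 nM and stands within the scatter of both measured neighbours: compound 1 `CN1C/C(=C\c2cccnc2)C(=O)/C(=C/c2ccccc2F)C1` at 4470 nM and compound 3 `CN1C/C(=C\c2ccncc2)C(=O)/C(=C/c2ccccc2C(F)(F)F)C1` at 4500 nM on the same read-out. The step of a 1.5-fold lower number from compound 1 to compound 2 (0.19 log units; within the scatter) puts trifluoromethyl in place of fluoro on an aromatic carbon. The step of a 1.5-fold higher number from compound 2 to compound 3 (0.19 log units; within the scatter) puts pyridin-4-yl in place of pyridin-3-yl. Both lie within the scatter.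

Relative to compound 2, compound 4 `O=C1/C(=C/c2cccnc2)CN(S(=O)(=O)c2ccc([N+](=O)[O-])cc2)C/C1=C\c1ccccc1C(F)(F)F` carries (4-nitrophenyl)sulfonyl in place of methyl on an amine nitrogen in a ring. Neither measured step touches that nitrogen, and together they give no size and no direction for this exchange. The estimate therefore starts from compound 2 at 2910 nM and expects no change beyond the scatter. In this assay the estimated step is a 1.5-fold lower number from compound 2 to compound 4 (0.16 log units; within the scatter) with a wide uncertainty. For compound 4 the estimated value is 2000 nM with an expected range from 500 nM to 8000 nM on this read-out.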

Compound 4, half-maximal inhibitory concentration: 7660 nM
For compound 4 the middle estimate is 3.8-fold (0.58 log units) below the measured one; the range from low to high includes it.
By their numbers in this assay, from the lowest: compounds 2, 1, 3 and 4 (each within the scatter of the next, the first and the last beyond it).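

For the compounds shown here, the ring nitrogen is the first position where a single exchange moves the number beyond the scatter: in this assay, replacing methyl with (4-nitrophenyl)sulfonyl gives a 2.6-fold higher number from compound 2 to compound 4 (0.42 log units; beyond the scatter). The step is modest for a change from methyl to a group with many more heavy atoms, so this amine nitrogen in a ring accepts a much larger substituent while compound 4 still gives a measurable value, at a weaker number than compound 2. Nothing available accounts for the direction or size of this step.

As far as these compounds go, it remains open whether the sulfonyl link or the 4-nitrophenyl ring carries the step, a question that methylsulfonyl or acetyl on the same nitrogen would help to settle. Also open, from the compounds shown here alone, is whether the same exchange gives a similar step on compound 1 or compound 3.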